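This account rests on a few compounds, and the source may have more. Where it says the series, first, only, none or still open, it means among the compounds named here.

Compound 1 `O=C(Nc1ccc(Oc2ccnc3[nH]ccc23)cc1)c1cn(-c2ccc(F)c(Cl)c2)c2ccccc2c1=O` and compound 2 `COc1ccc(-n2cc(C(=O)Nc3ccc(Oc4ccnc5[nH]ccc45)cc3)c(=O)c3ccccc32)cc1` share one core and differ in a single place. In a functional assay on MCF7 cells (Homo sapiens) for inhibition, read by MTT assay, with a stated time of 72 h (on this read-out higher numbers stand for weaker inhibition and lower numbers for stronger inhibition), compound 1 gives 1510 nM, and compound 2 gives 4650 nM. The change between them is 4-methoxyphenyl in place of 3-chloro-4-fluorophenyl on an aromatic nitrogen, and the step is a 3.1-fold higher number from compound 1 to compound 2 (0.49 log units; beyond the scatter).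

Compound 3 `Cn1ccc2c(Oc3ccc(NC(=O)c4cn(-c5ccc(F)c(Cl)c5)c5ccccc5c4=O)cc3F)ccnc21` belongs to a second core; the difference between the two cores is not broken down here. In this assay compound 3 gives "not determined" (no result reported), so no result was reported for it. Compound 4 `COc1ccc(-n2cc(C(=O)Nc3ccc(Oc4ccnc5c4ccn5C)c(F)c3)c(=O)c3ccccc32)cc1` has not yet been measured in this assay. It is made from compound 3 by the change (4-methoxyphenyl in place of 3-chloro-4-fluorophenyl on an aromatic nitrogen), which is the same change as that from compound 1 to compound 2, at a place described in the same words.

Since compound 3 has no number, the expectation for compound 4 rests on compound 2 alone, whose value 4650 nM marks the weaker end of the first pair, with the step of a 3.1-fold higher number from compound 1 to compound 2 (0.49 log units; beyond the scatter) suggesting the same kind of shift on the second core. Compound 4 is therefore expected to give about 5000 nM, estimated between 1500 nM and 20000 nM.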

Compound 4, half-maximal inhibitory concentration: 6720 nM
The estimate for compound 4 lay 1.3-fold (0.13 log units) below the measured number, and the stated range covers the measured number.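

With no single number for compound 3 in this assay, the step from compound 3 to compound 4 cannot be read. The compounds shown leave open whether 4-methoxyphenyl in place of 3-chloro-4-fluorophenyl shifts the number on the core of compound 3 as it does on the core of compound 1, where the step is a 3.1-fold higher number from compound 1 to compound 2 (0.49 log units; beyond the scatter). No evidence at hand bears on the result for compound 4.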